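The source may report more compounds than this note shows. Statements on the series, on what has been measured and on what is new or still open speak of the compounds shown alone.

Compound 1 `COc1cc(Cl)cc(-c2nn(-c3cccc(NC(=O)c4ccc(Cl)c(Cl)c4)c3)cc2-c2ccncc2)c1`: 54.6%
Compound 2 `COc1cc(Cl)cc(-c2nn(-c3cccc(NC(=O)Nc4ccc(Cl)c(Cl)c4)c3)cc2-c2ccncc2)c1`: 0.72%

In a functional assay on MDA-MB-468 cells (Homo sapiens) for inhibition, read by sulforhodamine B assay, with a stated time of 48 h, tested at 10 uM (on this read-out higher numbers stand for a weaker effect at the one concentration tested and lower numbers for a stronger effect), compound 1 stands highest of the two numbers shown. For the measured compounds named here, the only measured step, a number 53.9 percentage points lower from compound 1 to compound 2 (beyond the scatter), shows that adding an amino linker between the carbonyl carbon and the dichlorophenyl ring goes with a strong gain in effect. Compound 3 `COc1cc(Cl)cc(-c2nn(-c3cccc(NC(=O)Nc4cccc(C(F)(F)F)c4)c3)cc2-c2ccncc2)c1` differs from compound 1 in one place: (3-(trifluoromethyl)phenyl)amino in place of 3,4-dichlorophenyl on a carbonyl carbon. This change likewise inserts an amino linker, though the aryl group also changes, so that step bears directly on it. A large drop in the read-out is therefore expected, a number 44.6 percentage points lower from compound 1 to compound 3 (beyond the scatter), giving compound 3 an estimated 10% (range 0% to 40%).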

Compound 3, a percentage reported as activity, at one concentration (the size of the read-out at that concentration, not a potency): 6.89%
The estimate for compound 3 lay 3.1 percentage points above the measured number; the range from low to high includes it.
By their numbers in this assay, from the lowest: compounds 2 and 3 (each within the scatter of the next); then compound 1.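

In this assay, the gain seen earlier with a (3,4-dichlorophenyl)amino group on the carbonyl carbon also appears with (3-(trifluoromethyl)phenyl)amino, a number 47.7 percentage points lower from compound 1 to compound 3 (beyond the scatter), so it is not tied to a single aryl group. On the amide-type nitrogen, 3-(trifluoromethyl)phenyl and 3,4-dichlorophenyl cannot be told apart, a number 6.2 percentage points higher from compound 2 to compound 3 (within the scatter), so this position accepts both rings here.

On these data alone, whether a cyclohexyl group, a plain phenyl ring or a longer chain on that nitrogen would keep the effect stays open. The reason for these results also stays open, as no supporting measurements bear on them.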